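Changing the Amide Nitrogen Substituent Where Both Neighbours Sit at the Limit

A few compounds are considered here, and "the series" means these few. Any claim that something is new, unique, unknown or untested is made for them only; others in the source may bear on it.

Compound 1 `CNC(=O)c1cc(Oc2cccc(NC(=S)Nc3cccc(C(F)(F)F)c3)c2)ccn1` and compound 2 `O=C(NC1CCCCC1)c1cc(Oc2cccc(NC(=S)Nc3cccc(C(F)(F)F)c3)c2)ccn1` share one core and differ only in the group on the amide-type nitrogen. In a functional assay on MDA-MB-231 cells (Homo sapiens) for cytotoxicity, read by MTT assay, with a stated time of 48 h (on this read-out higher numbers stand for weaker inhibition and lower numbers for stronger inhibition), compound 1 gave only the limit of > 100000 nM, which is a limit of the assay rather than a number. In this assay compound 2 likewise gave only the limit of > 100000 nM, again a limit rather than a number. The step that the two limits leave unreadable from compound 1 to compound 2 therefore cannot be read, since (the limit of > 100000 nM in this assay, at which 2 of the 2 values shown sit). Compound 3 `O=C(c1cc(Oc2cccc(NC(=S)Nc3cccc(C(F)(F)F)c3)c2)ccn1)N1CCCC1` carries pyrrolidin-1-yl in place of cyclohexylamino on a carbonyl carbon. Among the measured compounds shown here, the only measured step at this position is unreadable, so no measured step shows a change here moving the read-out. Compound 3 is therefore expected to stay near the limit, with an estimated step that the limit leaves unreadable from compound 2 to compound 3 that is not expected to carry the value into the readable range. The estimate for compound 3 is 200000 nM, with a range from 50000 nM to 1000000 nM.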

Compound 3, half-maximal inhibitory concentration: 35400 nM
Compound 3: middle estimate off by 5.6-fold (0.75 log units), on the high side; the measured number lies below the stated range.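

Unlike the earlier pair, this change shows that the group on the carbonyl carbon can move the read-out in this assay: pyrrolidin-1-yl gives an at least 2.8-fold lower number from compound 2 to compound 3 (0.45 log units; beyond the scatter), and in place of methylamino it gives an at least 2.8-fold lower number from compound 1 to compound 3 (0.45 log units; beyond the scatter). Both steps are lower bounds rather than exact sizes: the limit of > 100000 nM in this assay, at which 2 of the 3 values shown sit. The step from compound 2 to compound 3 exchanges cyclohexylamino, with 1 hydrogen-bond donor, for pyrrolidin-1-yl, with 0, but that count and the change of ring are exchanged together, so this step cannot separate them.

From the compounds shown here alone, it remains open whether a similar drop in the number would come with a dimethylamino group, an open-chain group, or a piperidin-1-yl ring on the same carbonyl carbon. Going by these compounds, compound 3 alone has a readable value, so the true size of either step also remains open.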